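Nitro for Chloro, Measured Once and Expected Again

A few compounds are considered here, and "the series" means these few. Any claim that something is new, unique, unknown or untested is made for them only; others in the source may bear on it.

Compound 3 `CCOC(=O)C1=C(C)NC(=O)NC1c1cn(C(=O)CNc2ccc(Cl)cc2)c2ccccc12` gives 2.04 in a physicochemical assay for lipophilicity; on this read-out lower numbers stand for lower lipophilicity and higher numbers for higher lipophilicity. Compound 1 `CCOC(=O)C1=C(C)NC(=O)NC1c1cn(C(=O)CNc2ccc([N+](=O)[O-])cc2)c2ccccc12` gives 1.48 in this assay. For the measured compounds named here, the single change between them, (nitro in place of chloro on an aromatic carbon), made a step of a number 0.56 log units lower from compound 3 to compound 1 (beyond the scatter). Compound 2 `CCOC(=O)C1=C(C)NC(=S)NC1c1cn(C(=O)CNc2ccc(Cl)cc2)c2ccccc12` gives 3.44 in this assay, the highest of the three numbers; the difference between the core of compound 2 and the core of compound 3 is not broken down here. Compound 4 `CCOC(=O)C1=C(C)NC(=S)NC1c1cn(C(=O)CNc2ccc([N+](=O)[O-])cc2)c2ccccc12` carries the same change relative to compound 2, (nitro in place of chloro on an aromatic carbon), and awaits measurement in this assay. Going by the values given here, for compound 4 a step of a number 0.56 log units lower from compound 2 to compound 4 (beyond the scatter) is expected, beside the earlier one, because a number 0.56 log units lower from compound 3 to compound 1 (beyond the scatter) is the only measured instance of this change. Compound 4 is thus estimated at 2.88, expected to fall between 2.45 and 3.3.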

Compound 4, partition coefficient: 2.88
For compound 4 middle estimate and measured number coincide at the digits printed; low and high end bracket the measured number.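

In this assay, nitro in place of chloro on an aromatic carbon made a step of a number 0.56 log units lower from compound 2 to compound 4 (beyond the scatter) and so repeated the earlier a number 0.56 log units lower from compound 3 to compound 1 (beyond the scatter) in size, which means the change carried over between the two cores shown. For the compounds shown here, these are only two pairs, however, and they say nothing about how the change would behave on any other core. Nothing given here accounts for why the two steps agree.

The compounds shown leave open whether an amine or a carboxylic acid in place of chloro would also give steps that match across both cores. Also open, on these data alone, is whether a longer chain leading to the 4-nitrophenyl group would preserve this agreement.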